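From compound 2 to compound 3: one amide replacement

The source may hold more compounds than are shown below. What is called first, only, known or untested is meant among the compounds shown, and "the series" means these compounds.

Compound 2 `CNC(=O)CSc1nc2ccc(NC(C)=O)cc2s1` gives only a limit in a functional assay on MCF7 cells (Homo sapiens) for cytotoxicity, read by MTT assay, with a stated time of 48 h; a higher number here means a weaker inhibitor, a lower number a stronger inhibitor: > 100000 nM, which is a limit of the assay and not a number, so it sits at the limit of > 100000 nM in this assay, at which 1 of the 2 values shown sits. Compound 1 `O=C(CSc1nc2ccc(NC(=O)c3ccc(Cl)cc3)cc2s1)NCc1ccc(Cl)cc1` gives 29300 nM in this assay.

Compound 3 `CNC(=O)CSc1nc2ccc(NC(=O)c3ccc(Cl)cc3)cc2s1` differs from compound 2 by 4-chlorophenyl in place of methyl on a carbonyl carbon. Among the measured compounds shown here, no measured step between these two exists, so the size is uncertain. Compound 1 and compound 2 differ in more than one place; their values show only that the one carrying a 4-chlorophenyl on that carbonyl has a number where the acetyl compound has a limit. The step is expected to run toward stronger inhibition, an at least 1.6-fold lower number from compound 2 to compound 3 (0.22 log units; that floor lies within the scatter). Compound 3 is estimated at 60000 nM, between 20000 nM and 150000 nM.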

Compound 3, half-maximal inhibitory concentration: 29400 nM
For compound 3 the middle estimate is 2.0-fold (0.31 log units) above the measured one; low and high end bracket the measured number.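

Among the compounds shown here, with 4-chlorophenyl in place of methyl on a carbonyl carbon, this assay gives a measurable number for the first time in a single-change pair (an at least 3.4-fold lower number from compound 2 to compound 3 (0.53 log units; beyond the scatter)). Hydrogen in place of 4-chlorophenyl on the saturated chain carbon bound to an amide-type nitrogen leaves no difference beyond the scatter (a 1.0-fold higher number from compound 1 to compound 3 (0.00 log units; within the scatter)). The first step is only a floor, because compound 2 gives a limit of the assay: the limit of > 100000 nM in this assay, at which 1 of the 3 values shown sits.

As far as these compounds go, its true size remains open. Also open, from the compounds shown here alone, is whether the chlorine matters: an unsubstituted phenyl or a 4-aminophenyl on that carbonyl would separate chlorine from ring.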